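Trimming the ether chain: compound 3 to compound 4

The source may report more compounds than this note shows. Statements on the series, on what has been measured and on what is new or still open speak of the compounds shown alone.

Compound 3 `C=CCc1cc(OC)c(OC(C)C(OCCCCCCCCCC)c2ccc(O)c(OC)c2)c(OC)c1` stands second highest of the three numbers in an assay on HEK293 cells for agonist activity at transient receptor potential cation channel subfamily M member 8 (Homo sapiens), read by fluorescence and calcium flux, with a stated time of 5 min (a higher number here means that more compound is needed for the effect, a lower number that less compound is needed), with 66 nM. Compound 1 `C=CCc1cc(OC)c(OC(C)C(O[C@@H]2C[C@H](C)CC[C@H]2C(C)C)c2ccc(O)c(OC)c2)c(OC)c1` gives 28 nM, and compound 2 `C=CCc1cc(OC)c(OC(C)C(OCCCCCCCC)c2ccc(O)c(OC)c2)c(OC)c1` gives 86 nM. The steps of a 3.1-fold higher number from compound 1 to compound 2 (0.49 log units; beyond the scatter) and a 2.4-fold higher number from compound 1 to compound 3 (0.37 log units; beyond the scatter) run in the same direction, while a 1.3-fold lower number from compound 2 to compound 3 (0.11 log units; within the scatter) separates the two chain lengths by nothing that can be read. For the measured compounds named here, compound 4 `C=CCc1cc(OC)c(OC(C)C(OC)c2ccc(O)c(OC)c2)c(OC)c1` differs from compound 3 by hydrogen in place of nonyl on a saturated chain carbon bound to an oxygen on a saturated carbon, a far larger cut than the chain-length comparison, which is the only measured step directly bearing on it. The 2-isopropyl-5-methylcyclohexyl-to-chain steps were modest. A higher number is expected for compound 4, estimated as a 4.5-fold higher number from compound 3 to compound 4 (0.66 log units; beyond the scatter). The estimate for compound 4 in this assay is 300 nM, within 80 nM to 1500 nM.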

Compound 4, half-maximal effective concentration: 3450 nM
Estimate against measurement, compound 4: 12-fold (1.06 log units) below, outside the stated range (above it).
By their numbers in this assay, from the lowest: compound 1; then compounds 3 and 2 (each within the scatter of the next); then compound 4.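

In this assay the group on this oxygen matters far more than the octyl and decyl comparison could show, with a 52-fold higher number from compound 3 to compound 4 (1.72 log units; beyond the scatter) and a 40-fold higher number from compound 2 to compound 4 (1.60 log units; beyond the scatter) and also a 120-fold higher number from compound 1 to compound 4 (2.09 log units; beyond the scatter) on reaching methoxy. The steep part of the change therefore lies somewhere between methyl and octyl, not between the longer groups. Nothing at hand accounts for the size of this rise.

Where along that range the number climbs remains open, and a butyl or hexyl chain would place it. As far as these compounds go, whether a cyclohexyl ring without the isopropyl and methyl groups keeps the low number of compound 1 is also open.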